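The source may report more compounds than this note shows. Statements on the series, on what has been measured and on what is new or still open speak of the compounds shown alone.

Three compounds built on one shared core have been taken through a functional assay on the whole organism for inhibition, with Rattus norvegicus as the target, read by paw edema, with stated times of 30 min and 3 h, at a dose of 0.28 mmol/kg by the oral route; on this read-out lower numbers stand for less inhibition and higher numbers for more inhibition at the one dose given (going by the name of the read-out). Compound 1 `COc1ccc(-n2nc(C(=O)Nc3ccccc3OC)nc2-c2cc(OC)c(OC)c(OC)c2)cc1` gives 38% in this assay. Compound 2 `COc1ccc(-n2nc(C(=O)Nc3ccc(C)cc3)nc2-c2cc(OC)c(OC)c(OC)c2)cc1` gives 77%, and compound 3 `COc1ccc(-n2nc(C(=O)Nc3cccc(F)c3)nc2-c2cc(OC)c(OC)c(OC)c2)cc1` gives 92%. Compound 3 thus stands highest of the three numbers, with a number 15 percentage points higher from compound 2 to compound 3 (beyond the scatter) and a number 54 percentage points higher from compound 1 to compound 3 (beyond the scatter); the remaining step, a number 39 percentage points higher from compound 1 to compound 2 (beyond the scatter), also lies beyond the scatter. Every one of these steps exchanges the aryl group on the amide-type nitrogen, and every one shifted the read-out by a modest to large amount.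

Compound 4 `COc1ccc(-n2nc(C(=O)Nc3ccc(O)cc3)nc2-c2cc(OC)c(OC)c(OC)c2)cc1` has not yet been measured. It differs from compound 3 in one place: 4-hydroxyphenyl in place of 3-fluorophenyl on an amide-type nitrogen. For the measured compounds named here, none of the measured steps puts a 4-hydroxyphenyl on the amide-type nitrogen, so no step speaks directly to this change; the three steps show only that exchanges at this position have moved the read-out by modest to large amounts. Compound 3 stands highest of the numbers shown, which leaves more room downward than upward. Compound 4 is therefore expected to show a step of a number 22 percentage points lower from compound 3 to compound 4 (beyond the scatter). In this assay compound 4 is estimated to give about 70%, within a range from 45% to 92%.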

Compound 4, a percentage reported as inhibition, in the whole organism at one dose (the size of the read-out at that dose, not a potency): 64%
Compound 4: middle estimate off by 6 percentage points, on the high side; measured number inside the range.
By their numbers in this assay, from the lowest: compound 1; then compound 4; then compound 2; then compound 3.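

In this assay, the 4-hydroxyphenyl group on the amide-type nitrogen lands within the span already set by the earlier aryl groups, with a number 28 percentage points lower from compound 3 to compound 4 (beyond the scatter) and a number 26 percentage points higher from compound 1 to compound 4 (beyond the scatter). Hydroxy in place of methyl on an aromatic carbon gives a number 13 percentage points lower from compound 2 to compound 4 (beyond the scatter), the first step here that changes one substituent while the name of its place on the ring, the 4 of both groups, stays the same. No evidence is available that accounts for any of these steps.

Going by these compounds, what a 4-fluorophenyl or a 3-hydroxyphenyl would give on the amide-type nitrogen stays open, so the effect of a group cannot yet be separated from that of its place on the ring. Also open, on these data alone, is the outcome with an amine or a carboxylic acid on that aryl ring.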